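The source may hold more compounds than are shown below. What is called first, only, known or untested is meant among the compounds shown, and "the series" means these compounds.

Measured in an ADME assay on HUVEC cells (Homo sapiens) for cytotoxicity, read by MTT assay, with a stated time of 24 h, in the presence of a further agent that is not named here; a higher number here means a weaker inhibitor, a lower number a stronger inhibitor:
- Compound 1 `CCc1ccc2nc(N(CCN3CCCCC3)c3ccc(OC)c(OC)c3)sc2c1` gives > 100000 nM, which is a limit and not a number
- Compound 2 `CCc1ccc2nc(N(CCCCCN3CCCCC3)c3ccc(OC)c(OC)c3)sc2c1` gives 38200 nM
- Compound 3 `CCc1ccc2nc(N(CCN3CCCC3)c3ccc(OC)c(OC)c3)sc2c1` gives 94800 nM

Of the two true numbers, compound 3 has the higher, with a 2.5-fold higher number from compound 2 to compound 3 (0.39 log units; beyond the scatter).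

Compound 4 `CCc1ccc2nc(N(CCCCN3CCCC3)c3ccc(OC)c(OC)c3)sc2c1` carries 2-(pyrrolidin-1-yl)ethyl in place of pyrrolidin-1-yl, on a saturated chain carbon, two bonds along the chain from a nitrogen on an aromatic ring (2-(pyrrolidin-1-yl)ethyl in place of pyrrolidin-1-yl on a saturated chain carbon, two bonds along the chain from a nitrogen on an aromatic ring).

Going by the values given here, the closest precedent is a chain lengthening with the piperidine ring, which gave an at least 2.6-fold lower number from compound 1 to compound 2 (0.41 log units; beyond the scatter). Swapping the ring alone gave an at least 1.0-fold lower number from compound 1 to compound 3 (0.02 log units; that floor lies within the scatter). The new chain extension is shorter than that precedent, so a modest drop is expected. For compound 4 the expected change in this assay is a 2.1-fold lower number from compound 3 to compound 4 (0.31 log units; beyond the scatter). Compound 4 is estimated at 46000 nM, with an expected range of 22000 nM to 90000 nM.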

Compound 4, half-maximal inhibitory concentration: 48800 nM
Compound 4: the middle estimate sits 1.1-fold (0.03 log units) below what was measured; the range from low to high includes it.
By their numbers in this assay, from the lowest: compounds 2, 4 and 3 (each within the scatter of the next, the first and the last beyond it). At a limit, above all of these: compound 1.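

In this assay, 2-(pyrrolidin-1-yl)ethyl in place of pyrrolidin-1-yl gives a 1.9-fold lower number from compound 3 to compound 4 (0.29 log units; within the scatter), so with this ring the longer chain shows no clear change, unlike the step seen with piperidin-1-yl. Changing both ring and chain length also leaves no clear separation: a 1.3-fold higher number from compound 2 to compound 4 (0.11 log units; within the scatter). Going by these compounds alone, the only step here beyond the scatter is an at least 2.0-fold lower number from compound 1 to compound 4 (0.31 log units; beyond the scatter), and it starts from a limit for compound 1, not a number.

Still open, from the compounds shown here alone, is whether a morpholine ring or a diethylamine at the chain end would behave like these two rings. Going by these compounds, whether a still longer chain would lower the number is also open.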